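Chalcone-bearing dithiocarbamates: swapping the distal aryl substituent

The source may hold more compounds than are shown below. What is called first, only, known or untested is meant among the compounds shown, and "the series" means these compounds.

Measured so far in this assay:
compound 1, `CC(=O)c1ccc(NC(=O)CSC(=S)N[C@H]2CCOC2=O)cc1`: > 128000 nM
compound 2, `O=C(CSC(=S)N[C@H]1CCOC1=O)Nc1ccc(C(=O)/C=C/c2cccc(Cl)c2)cc1`: 32500 nM

In a functional assay on EC9706 cells (Homo sapiens) for cytotoxicity, read by MTT assay, with a stated time of 72 h (a lower number here means a stronger inhibitor, a higher number a weaker inhibitor), compound 1 is reported only as a limit of the assay, > 128000 nM (the limit of > 128000 nM in this assay, at which 1 of the 2 values shown sits). Among the compounds with values here, compound 2 gives 32500 nM in this assay, and this is the only numerical value in the set so far. Within the data shown here, the sole measured step, an at least 3.9-fold lower number from compound 1 to compound 2 (0.59 log units; beyond the scatter), concerns the enlargement of the group on the carbonyl carbon and says nothing about which substituent the added ring carries.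

Compound 3, `O=C(CSC(=S)N[C@H]1CCOC1=O)Nc1ccc(C(=O)/C=C/c2ccc([N+](=O)[O-])cc2)cc1`, differs from compound 2 by 4-nitrophenyl in place of 3-chlorophenyl on a double-bonded chain carbon bound to a double-bonded chain carbon. Among the measured compounds shown here, no measured step bears directly on exchanging one ring substituent for another at this position, so there is no basis here for expecting a shift beyond the scatter in either direction. The working expectation is that compound 3 sits close to compound 2, with the step of a 1.1-fold lower number from compound 2 to compound 3 (0.03 log units; within the scatter) expected to be small. Compound 3 is therefore estimated at 30000 nM in this assay, within 10000 nM to 100000 nM.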

Compound 3, half-maximal inhibitory concentration: > 128000 nM
Compound 3: only a limit was reported; the forecaster's own chance of this, stated with the estimate: 15%; middle value at least 4.2-fold (0.63 log units) from the limit.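

In this assay compound 3 is reported only as a limit of the assay, > 128000 nM. Exchanging 3-chlorophenyl for 4-nitrophenyl on a double-bonded chain carbon bound to a double-bonded chain carbon gives an at least 3.9-fold higher number from compound 2 to compound 3 (0.59 log units; beyond the scatter), so the measurable number of compound 2 depends on what the ring carries and not only on the enlargement of the group on the carbonyl carbon. The step from compound 1 to compound 3 cannot be read, and a 2-arylethenyl group in place of methyl does not by itself bring a compound to a numerical value, as 2-(4-nitrophenyl)ethenyl shows: the limit of > 128000 nM in this assay, at which 2 of the 3 values shown sit.

Compound 2 and compound 3 differ in both the ring substituent and its printed ring number, so the compounds shown do not separate chlorine from nitro or the 3-substituted ring from the 4-substituted one; 4-chlorophenyl and 3-nitrophenyl would do so. Also open, as far as these compounds go, is how far the number moves with unsubstituted phenyl, or with a ring carrying methoxy or an amine, and whether any ring at this place gives a value much lower than that of compound 2.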